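Benzyl for benzyloxymethyl on a cyclic sulfonamide nitrogen

The source may report more compounds than this note shows. Statements on the series, on what has been measured and on what is new or still open speak of the compounds shown alone.

Three compounds share one core. Within the data shown here, compound 1 `O=C1c2ccccc2N(COCc2ccccc2)S(=O)(=O)N1COCc1ccccc1` is the only one that returns a number in a functional assay on HEL cells (Homo sapiens) for inhibition (on this read-out lower numbers stand for higher toxicity in this test and higher numbers for lower toxicity in this test), where compound 1 gives 130000 nM. Compound 2 `O=C1c2ccccc2N(Cc2ccccc2Cl)S(=O)(=O)N1Cc1ccccc1Cl` reaches only a limit of the assay, and in this assay compound 2 gives > 200000 nM. Compound 3 `C#CCOCN1c2ccccc2C(=O)N(Cc2ccccc2)S1(=O)=O` likewise returns only a limit, and in this assay compound 3 gives > 140000 nM. Among the measured compounds shown here, no two of the measured compounds differ in a single place, so no step between them can be read, and compound 1 stands simply as the one measured number among two limits.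

Compound 4 `O=C1c2ccccc2N(Cc2ccccc2)S(=O)(=O)N1COCc1ccccc1` is not yet measured. It differs from compound 1 by phenyl in place of benzyloxy on a saturated chain carbon bound to a sulfonamide nitrogen in a ring. For the measured compounds named here, with no measured step to lean on, the change from compound 1 to compound 4 in this assay is expected to be small, in no particular direction and not beyond the usual scatter. Compound 4 is therefore expected to give about 150000 nM, within a range from 60000 nM to 300000 nM. This corresponds to an expected step of a 1.2-fold higher number from compound 1 to compound 4 (0.06 log units; within the scatter).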

Compound 4, half-maximal cytotoxic concentration: > 98000 nM
Compound 4 gave a limit, no number (the forecaster's own chance of this, stated with the estimate: 40%); the middle value lies beyond the limit too.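

Compound 4 returns only a limit in this assay, > 98000 nM, so the step from compound 1 to compound 4 cannot be read. The compounds shown leave open whether phenyl in place of benzyloxy at this place changes the read-out at all, and compound 1 remains the only one with a number.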